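Replacing 2,4-dichlorophenyl with 4-bromophenyl in compound 2

This account rests on a few compounds, and the source may have more. Where it says the series, first, only, none or still open, it means among the compounds named here.

Measured in a functional assay on K562 cells (Homo sapiens) for inhibition, read by MTT assay, with a stated time of 48 h; a lower number here means a stronger inhibitor, a higher number a weaker inhibitor:
- compound 1 `Nc1n[nH]c2cc(-c3cn([C@@H]4CN[C@H](C(=O)Nc5ccc(Br)cc5)C4)nn3)ccc12`: 10300 nM
- compound 2 `Nc1nc2ccc(-c3cn([C@@H]4CN[C@H](C(=O)Nc5ccc(Cl)cc5Cl)C4)nn3)nc2s1`: 24500 nM

Compound 2, at 24500 nM, has the higher of the two numbers, and its gap to compound 1 lies beyond the usual scatter. Compound 3 `Nc1nc2ccc(-c3cn([C@@H]4CN[C@H](C(=O)Nc5ccc(Br)cc5)C4)nn3)nc2s1` keeps the core of compound 2 and differs from it in one place: 4-bromophenyl in place of 2,4-dichlorophenyl on an amide-type nitrogen. Within the data shown here, no two measured compounds differ in only one place, so this change has not been tested on its own. Compound 1 carries 4-bromophenyl on a different core and gives 10300 nM, which points to a small expected move towards a lower number in this assay, hardly beyond the scatter. The expected step is a 1.5-fold lower number from compound 2 to compound 3 (0.19 log units; within the scatter). For compound 3 the estimate is 16000 nM, with an expected range of 7000 nM to 35000 nM.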

Compound 3, half-maximal inhibitory concentration: 24400 nM
Compound 3: middle estimate off by 1.5-fold (0.18 log units), on the low side; measured number inside the range.
By their numbers in this assay, from the lowest: compound 1; then compounds 3 and 2 (each within the scatter of the next).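

In this assay, putting 4-bromophenyl in place of 2,4-dichlorophenyl on the amide-type nitrogen gives a 1.0-fold lower number from compound 2 to compound 3 (0.00 log units; within the scatter) and so leaves the read-out unmoved on this core, even though the group loses one halogen and changes the other. Among these compounds, with 4-bromophenyl held constant, the change of core gives a 2.4-fold higher number from compound 1 to compound 3 (0.37 log units; beyond the scatter) and is therefore the only single change here that lies beyond the scatter. Nothing measured here explains either result.

Going by these compounds, it remains open whether 2,4-dichlorophenyl and 4-bromophenyl would also match on the core of compound 1, since one matched pair on one core cannot settle that. On these data alone, it is also open whether this position would respond to a group of a different kind, such as cyclohexyl or a phenyl ring carrying a carboxylic acid.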